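Tert-butyl ester in place of acetate on the long chain

The source may hold more compounds than are shown below. What is called first, only, known or untested is meant among the compounds shown, and "the series" means these compounds.

In a functional assay on MOLT-4F cells (Homo sapiens) for antiproliferative activity (a higher number here means a weaker inhibitor of growth, a lower number a stronger inhibitor of growth), compound 1 `COCCCCCCCCCCC/C=C1\CC(CO)(COC(=O)C(C)(C)C)OC1=O` gives 2.38 ug/mL and compound 2 `CC(=O)OCCCCCCCCCCCCCCC/C=C1\CC(CO)(COC(=O)C(C)(C)C)OC1=O` gives 1.55 ug/mL. Going by the values given here, these are the only two numbers so far. They lie within the scatter of each other, so compound 2 cannot be ranked apart from compound 1.

Compound 3 `CC(C)(C)C(=O)OCCCCCCCCCCCCCCC/C=C1\CC(CO)(COC(=O)C(C)(C)C)OC1=O` keeps the shared core and differs from compound 2 in one place: tert-butyl in place of methyl on a carbonyl carbon. This is tert-butyl in place of methyl on a carbonyl carbon, which turns acetoxy into ((tert-butyl)carbonyl)oxy.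

Among the compounds with values here, no measured pair holds this change itself. Within the data shown here, the one measured step, a 1.5-fold lower number from compound 1 to compound 2 (0.19 log units; within the scatter), replaces a different group and stays within the scatter, so it offers only indirect guidance. It gives no basis for a direction, and no shift beyond the scatter is expected in this assay. The estimated step is a 1.0-fold higher number from compound 2 to compound 3 (0.01 log units; within the scatter). For compound 3 the expected value is 1.6 ug/mL, with an estimated range of 0.8 ug/mL to 3.2 ug/mL.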

Compound 3, concentration for 50% growth inhibition: 0.605 ug/mL
Beside the measured number, compound 3's estimate is 2.6-fold (0.42 log units) above it; measured number below the stated range.
By their numbers in this assay, from the lowest: compound 3; then compounds 2 and 1 (each within the scatter of the next).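

Working notes on the chain end. In this assay, going by these compounds alone, the acyl group on the ester at the far end of the long chain matters: tert-butyl in place of methyl on a carbonyl carbon gives a step beyond the scatter (a 2.6-fold lower number from compound 2 to compound 3 (0.41 log units; beyond the scatter)), whereas the only earlier step stayed within it. The change from the methoxy-ended chain to the longer chain carrying 4-(((tert-butyl)carbonyl)oxy)butyl is also beyond the scatter (a 3.9-fold lower number from compound 1 to compound 3 (0.59 log units; beyond the scatter)), so compound 3 now stands apart from both other compounds as the strongest inhibitor of growth of the three. No measurement at hand accounts for this gain.

From the compounds shown here alone, the series compares only acetyl and (tert-butyl)carbonyl on this oxygen, so it remains open whether the lower number tracks the branched acyl group specifically or would also appear with isopropylcarbonyl or benzoyl. Also open, going by these compounds, is how a free hydroxyl or an amide at the chain end would compare, and whether a shorter chain carrying the same (tert-butyl)carbonyl ester would hold the number of compound 3 (0.605 ug/mL).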